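The source may report more compounds than this note shows. Statements on the series, on what has been measured and on what is new or still open speak of the compounds shown alone.

Working notes on the series. In a functional assay on MDA-MB-231 cells (Homo sapiens) for inhibition, read by MTT assay, with a stated time of 72 h (on this read-out lower numbers stand for stronger inhibition and higher numbers for weaker inhibition), compound 1 `CC(C)(C)n1cc2c(n1)C(=O)CC1(CCN(C(=O)c3cc(-c4ccccc4)nc4ccccc34)CC1)O2` reads > 10000 nM, which is a limit of the assay. Within the data shown here, compound 2 `CC(C)(C)n1cc2c(n1)C(=O)CC1(CCN(C(=O)c3cc(-c4ccncc4)nc4ccccc34)CC1)O2` gives 1650 nM, so far the only actual number. Compound 3 `CC(C)(C)n1cc2c(n1)C(=O)CC1(CCN(C(=O)c3cc(N4CCNCC4)nc4ccccc34)CC1)O2` carries the next change, piperazin-1-yl in place of pyridin-4-yl on an aromatic carbon, next to the ring nitrogen. Among the measured compounds shown here, one measured step bears on this place, the swap of phenyl for pyridin-4-yl, and it is an at least 6.0-fold lower number from compound 1 to compound 2 (0.78 log units; beyond the scatter). That step shows the number can respond to a change here, but it does not cover piperazin-1-yl, and its full size is hidden by the limit of > 10000 nM in this assay, at which 1 of the 2 values shown sits. No step beyond the scatter is therefore expected in this assay, though a move in either direction remains possible. The expected step is a 1.2-fold higher number from compound 2 to compound 3 (0.08 log units; within the scatter). For compound 3 the estimate is 2000 nM, with an expected range from 400 nM to 9000 nM.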

Compound 3, half-maximal inhibitory concentration: 4200 nM
For compound 3 the middle estimate is 2.1-fold (0.32 log units) below the measured one; measured number inside the range.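

In this assay this position also gives a measurable number with a non-aromatic ring, so an aromatic ring here is not needed for activity among these compounds. Piperazin-1-yl still falls short of pyridin-4-yl, with a 2.5-fold higher number from compound 2 to compound 3 (0.41 log units; beyond the scatter), while it improves on phenyl, with an at least 2.3-fold lower number from compound 1 to compound 3 (0.37 log units; beyond the scatter), which leaves compound 2 the most potent of the three. The second of these steps gives only a lower bound on its size because of a limit: the limit of > 10000 nM in this assay, at which 1 of the 3 values shown sits.

On these data alone, whether the extra ring nitrogen and its hydrogen in piperazin-1-yl are what sets the number remains open, and morpholin-4-yl or 4-methylpiperazin-1-yl at this position would bear on that. As far as these compounds go, it is also open how pyridin-3-yl would compare with pyridin-4-yl here.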